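The source may report more compounds than this note shows. Statements on the series, on what has been measured and on what is new or still open speak of the compounds shown alone.

Measured in an assay on HEK293 cells for displacement of a labelled ligand from prostaglandin D2 receptor 2 (Homo sapiens); a higher number here means a weaker inhibitor, a lower number a stronger inhibitor:
compound 1 `O=C(O)Cn1c(SCc2ccc(Cl)cc2)nc2ccccc21`: 160 nM
compound 2 `COC(=O)c1ccc(CSc2nc3ccccc3n2CC(=O)O)cc1`: 10600 nM

Compound 1 gives the lower of the two numbers in this assay. For the measured compounds named here, the single measured step, a 66-fold higher number from compound 1 to compound 2 (1.82 log units; beyond the scatter), is the only reference point, and it concerns the exchange of the chloro itself for a methoxycarbonyl.

Compound 3 `O=C(O)Cn1c(SCc2ccc(Cl)c(Cl)c2)nc2ccccc21` differs from compound 1 by chloro in place of hydrogen on an aromatic carbon. Going by the values given here, no measured step adds a chloro while the first chloro is kept, so the step from compound 1 to compound 2 bears on this change only loosely: it shows that the chloro position tolerates little when the chloro is replaced by a larger group, but says nothing direct about a second chloro. Among the compounds with values here, with no closer precedent, the step in this assay is expected to stay within the scatter, in either direction. Compound 3 is therefore estimated at about 130 nM, with a range from 45 nM to 400 nM. The expected step of a 1.2-fold lower number from compound 1 to compound 3 (0.09 log units; within the scatter) is within the scatter.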

Compound 3, half-maximal inhibitory concentration: 380 nM
Estimate against measurement, compound 3: 2.9-fold (0.47 log units) below; the range from low to high includes it.
By their numbers in this assay, from the lowest: compound 1; then compound 3; then compound 2.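

Compound 2 spoke only to replacing the chloro itself; with the first chloro kept, the new result shows that this ring still responds to an added group. In this assay, a chloro ortho to a chloro group gives a 2.4-fold higher number from compound 1 to compound 3 (0.38 log units; beyond the scatter), a modest loss beside a 66-fold higher number from compound 1 to compound 2 (1.82 log units; beyond the scatter), so this place accepts the added chloro with some cost and compound 1 keeps the lowest number. No measured data explain this step.

From the compounds shown here alone, whether a fluoro, a methyl or a methoxy at this same place would give a similar step remains open, as does the effect of a lone chloro here without the first chloro. Changes elsewhere on the shared core, such as a longer chain carrying the carboxylic acid or an amide in place of that acid, also remain open.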